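This account rests on a few compounds, and the source may have more. Where it says the series, first, only, none or still open, it means among the compounds named here.

Three measured compounds share one core and differ only in the group carried on the sulfur. Compound 1 `O=C(O)Cn1c(SCCCCOc2ccccc2)nc2ccccc21` gives 1400 nM in an assay on HEK293 cells for displacement of a labelled ligand from prostaglandin D2 receptor 2 (Homo sapiens); on this read-out higher numbers stand for weaker inhibition and lower numbers for stronger inhibition. Compound 2 `CCCCCSc1nc2ccccc2n1CC(=O)O` gives 1240 nM in this assay, and compound 3 `CCOC(=O)CCCCSc1nc2ccccc2n1CC(=O)O` gives 2360 nM. Compound 2 has the lowest of the three numbers, but its nearest neighbour compound 1 and its furthest neighbour compound 3 both sit within the scatter of it, so no order among the three can be read from these values.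

The three measured steps all alter the far end of the chain: a 1.1-fold lower number from compound 1 to compound 2 (0.05 log units; within the scatter), a 1.7-fold higher number from compound 1 to compound 3 (0.23 log units; within the scatter) and a 1.9-fold higher number from compound 2 to compound 3 (0.28 log units; within the scatter). Each of them stays within the scatter.

Compound 4 `Cc1ccccc1CSc1nc2ccccc2n1CC(=O)O` has not been measured. From compound 2 it differs by 2-methylphenyl in place of butyl on a saturated chain carbon bound to a sulfur. Among the compounds with values here, none of the measured steps touches the carbon bound to the sulfur, and none replaces the whole chain with a ring, so they bear on this change only loosely; what they do show is that varying the group on the sulfur has so far left the number roughly in place. The expected step of a 1.0-fold lower number from compound 2 to compound 4 (0.01 log units; within the scatter) is therefore one of no clear size beyond the scatter. Compound 4 is estimated at 1200 nM, with a range from 400 nM to 3600 nM.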

Compound 4, half-maximal inhibitory concentration: 810 nM
Beside the measured number, compound 4's estimate is 1.5-fold (0.17 log units) above it; measured number inside the range.
By their numbers in this assay, from the lowest: compounds 4, 2, 1 and 3 (each within the scatter of the next, the first and the last beyond it).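

Putting 2-methylphenyl in place of butyl on a saturated chain carbon bound to a sulfur gives a 1.5-fold lower number from compound 2 to compound 4 (0.18 log units; within the scatter) in this assay, so this swap moves the number no further than repeated measurements might. The earlier steps shown here altered only the far end of the chain, whereas this one reaches the carbon bound to the sulfur and replaces an open chain with a six-membered aromatic ring of carbon only. The position therefore keeps its number within the scatter when a group of seven carbons with a ring enters for a group of four carbons without one, although this rests on a single pair and shows no gain in inhibition.

On these data alone, it remains open what a plain phenyl group would give on this carbon, whether the methyl of 2-methylphenyl matters, and how a ring carrying an amine or a carboxylic acid, or a longer chain between the ring and the sulfur, would behave. Nothing available explains why the ring is accepted here.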